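Notes on replacing bromo with carboxy

A few compounds are considered here, and "the series" means these few. Any claim that something is new, unique, unknown or untested is made for them only; others in the source may bear on it.

Measured so far in a functional assay on A549 cells (Homo sapiens) for cytotoxicity, read by sulforhodamine B assay; a lower number here means a stronger inhibitor, a higher number a weaker inhibitor
- compound 1 `C=C1[C@@H](OC(C)=O)C[C@@H]2[C@](C)(COC=O)[C@H](OC(C)=O)CC[C@@]2(C)[C@@H]1C[C@@H](Nc1ccccc1)C1=CCOC1=O` gives 25800 nM
- compound 2 `C=C1[C@@H](OC(C)=O)C[C@@H]2[C@](C)(COC=O)[C@H](OC(C)=O)CC[C@@]2(C)[C@@H]1C[C@@H](Nc1ccc(Br)cc1)C1=CCOC1=O` gives 15900 nM

Compound 2 lies within the scatter of compound 1, so these two values do not rank the compounds. Compound 3 `C=C1[C@@H](OC(C)=O)C[C@@H]2[C@](C)(COC=O)[C@H](OC(C)=O)CC[C@@]2(C)[C@@H]1C[C@@H](Nc1ccc(C(=O)O)cc1)C1=CCOC1=O` carries carboxy in place of bromo on an aromatic carbon, para to a large group (carboxy in place of bromo on an aromatic carbon). Going by the values given here, the only measured step on this aromatic carbon is bromo in place of hydrogen, which gave a 1.6-fold lower number from compound 1 to compound 2 (0.21 log units; within the scatter) and so offers no sign of a strong dependence on this substituent. Among the compounds with values here, no compound with carboxy has been measured, so this guide is weak. The estimate is a 1.4-fold higher number from compound 2 to compound 3 (0.14 log units; within the scatter) in this assay and this expected step stays within the scatter, with a slight upward lean at most. The estimated value for compound 3 is 22000 nM (expected range 10000 nM to 50000 nM).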

Compound 3, half-maximal inhibitory concentration: > 50000 nM
Compound 3: a limit, no number (the forecaster's own chance of this, stated with the estimate: 15%); middle value at least 2.2-fold (0.35 log units) away from the limit.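

In this assay the value of compound 3 is a limit and not a number: the limit of > 50000 nM in this assay, at which 1 of the 3 values shown sits.

Even so, this aromatic carbon now shows a dependence on its substituent that bromo in place of hydrogen did not show: carboxy in place of bromo gives an at least 3.1-fold higher number from compound 2 to compound 3 (0.49 log units; beyond the scatter). Carboxy in place of hydrogen gives an at least 1.9-fold higher number from compound 1 to compound 3 (0.28 log units; that floor lies within the scatter), a floor that does not settle the order of that pair.

Going by these compounds, the true size of both steps stays open while the limit stands. Also open, on these data alone, is whether a methyl ester, a primary amide or an amine on this aromatic carbon would track with bromo or with carboxy, and whether hydrogen and bromo are the only substituents here that leave the number in the range of the first two compounds.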